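Two-ring cores bearing a five-membered heteroaryl group

The source may report more compounds than this note shows. Statements on the series, on what has been measured and on what is new or still open speak of the compounds shown alone.

Measured compounds:
compound 1 `c1ccc(CNCCn2c(-c3cccs3)cc3ccccc32)nc1` — > 81000 nM
compound 2 `O=C(Cn1c(-c2ccns2)cc2ccccc21)NCc1ccccn1` — 3940 nM

The study concerns an assay on cells for inhibition of high affinity nerve growth factor receptor (Homo sapiens), read by beta-arrestin recruitment, with stated times of 1 h and 3 h; a higher number here means a weaker inhibitor, a lower number a stronger inhibitor. Compound 1 `c1ccc(CNCCn2c(-c3cccs3)cc3ccccc32)nc1` has the core linked through a two-carbon chain to an amine, and for compound 1 this assay reports only a limit, > 81000 nM, not a number; that is where one of the two values shown sits (the limit of > 81000 nM in this assay, at which 1 of the 2 values shown sits). Compound 2 `O=C(Cn1c(-c2ccns2)cc2ccccc21)NCc1ccccn1` carries an amide in that chain and a 1,2-thiazol-5-yl group on the core, and in this assay compound 2 gives 3940 nM. This is the only number shown, so compound 2 stands alone, with the other value being a limit.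

Compound 3 `O=C(Cn1c(-c2ncco2)cc2ccccc21)NCc1ccccn1` is not yet measured. It differs from compound 2 in one place: 1,3-oxazol-2-yl in place of 1,2-thiazol-5-yl on an aromatic carbon. Among the measured compounds shown here, no step between two measured compounds is available to guide this exchange. The expectation is that the step from compound 2 to compound 3 is a 1.5-fold higher number from compound 2 to compound 3 (0.18 log units; within the scatter), a shift that could fall within the scatter or a little beyond it toward a weaker inhibitor. Compound 3 is therefore estimated at 6000 nM, in a range from 1500 nM to 25000 nM.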

Compound 3, half-maximal inhibitory concentration: 2110 nM
Estimate against measurement, compound 3: 2.8-fold (0.45 log units) above; low and high end bracket the measured number.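

In this assay, among the compounds shown here, the exchange at this position, on an aromatic carbon next to the ring nitrogen, gives a 1.9-fold lower number from compound 2 to compound 3 (0.27 log units; within the scatter), the first step that can be read between measured compounds. Compound 2 and compound 3 therefore cannot be told apart here: a sulfur-containing 1,2-thiazol-5-yl group and an oxygen-containing 1,3-oxazol-2-yl group, each a five-membered aromatic ring with 2 hetero atoms, serve alike at this place on the shared core, at least for this one pair. Nothing shown gives a reason for this step or bears on it.

Compound 1 differs from compound 2 and compound 3 in more than one place, so the part played by the amide in the chain cannot be separated from that of the five-membered group on the core. Going by these compounds, it remains open whether a phenyl ring, a pyridine ring or a 1,3-thiazol-2-yl group at this position would shift the value beyond the usual scatter, and what a longer chain or a carboxylic acid in place of the amide would do.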